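From Methyl to tert-Butoxy on the Shared Core

A few compounds are considered here, and "the series" means these few. Any claim that something is new, unique, unknown or untested is made for them only; others in the source may bear on it.

In a functional assay on MCF7 cells (Homo sapiens) for inhibition, read by MTT assay, with a stated time of 72 h (a higher number here means a weaker inhibitor, a lower number a stronger inhibitor), compound 1 `COc1ccc(-c2nnc(SCCCN3CCN(c4nc5ccccc5o4)CC3)o2)cc1` gives 52800 nM, compound 2 `Cc1ccc(-c2nnc(SCCCN3CCN(c4nc5ccccc5o4)CC3)o2)cc1` gives 60400 nM, and compound 3 `Fc1ccc(-c2nnc(SCCCN3CCN(c4nc5ccccc5o4)CC3)o2)cc1` gives 52300 nM. Compound 2 therefore stands level with the other two, as the measured steps show: a 1.1-fold higher number from compound 1 to compound 2 (0.06 log units; within the scatter), a 1.2-fold lower number from compound 2 to compound 3 (0.06 log units; within the scatter) and a 1.0-fold lower number from compound 1 to compound 3 (0.00 log units; within the scatter). Compound 4 `CC(C)(C)Oc1ccc(-c2nnc(SCCCN3CCN(c4nc5ccccc5o4)CC3)o2)cc1` has tert-butoxy in place of methyl on an aromatic carbon. For the measured compounds named here, no measured compound carries tert-butoxy, so the data hold no direct step for this change. All three substituent swaps measured so far stayed within the scatter, so no shift beyond it is expected. The estimated step is a 1.2-fold lower number from compound 2 to compound 4 (0.08 log units; within the scatter). Compound 4 is expected at 50000 nM, with an estimated range of 22000 nM to 100000 nM.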

Compound 4, half-maximal inhibitory concentration: 94900 nM
Estimate against measurement, compound 4: 1.9-fold (0.28 log units) below, and the stated range covers the measured number.
By their numbers in this assay, from the lowest: compounds 3, 1, 2 and 4 (each within the scatter of the next).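

In this assay the earlier swaps involved only methyl, methoxy and fluoro, whereas tert-butoxy is a much larger group by heavy atoms, and the steps still stay within the scatter: a 1.6-fold higher number from compound 2 to compound 4 (0.20 log units; within the scatter) and a 1.8-fold higher number from compound 3 to compound 4 (0.26 log units; within the scatter) and a 1.8-fold higher number from compound 1 to compound 4 (0.25 log units; within the scatter) on this carbon, para to a large group. Size at this position, across these four compounds, therefore produces no change that can be told from scatter. No measurement here offers an explanation for these numbers. On these data alone, whether an amine or a carboxylic acid at this position would give a step beyond the scatter remains open.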